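The source may hold more compounds than are shown below. What is called first, only, known or untested is meant among the compounds shown, and "the series" means these compounds.

In an ADME assay on HEK-293T cells (Homo sapiens) for cytotoxicity, read by MTT assay, with a stated time of 24 h (on this read-out higher numbers stand for lower toxicity in this test and lower numbers for higher toxicity in this test), compound 1 (`O=S(=O)(c1ccc(F)cc1)n1c(-c2cn(-c3ccccc3)nc2-c2ccc(F)cc2)nc2ccccc21`) gives 218000 nM and compound 2 (`O=S(=O)(c1ccccc1)n1c(-c2cn(-c3ccccc3)nc2-c2ccc(C(F)(F)F)cc2)nc2ccccc21`) gives 128000 nM on the same scale. Compound 3 (`COc1ccc(S(=O)(=O)n2c(-c3cn(-c4ccccc4)nc3-c3ccc(C(F)(F)F)cc3)nc3ccccc32)cc1`) gives > 300000 nM as a limit of the assay and not a number. Its place is thus fixed only by the limit of > 300000 nM in this assay, at which 1 of the 3 values shown sits, and not by an exact reading.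

Compound 4 (`O=S(=O)(c1ccc(F)cc1)n1c(-c2cn(-c3ccccc3)nc2-c2ccc(C(F)(F)F)cc2)nc2ccccc21`) differs from compound 3 in one place: fluoro in place of methoxy on an aromatic carbon (fluoro in place of methoxy on an aromatic carbon, para to a large group). For the measured compounds named here, the one measured step at this spot is an at least 2.3-fold higher number from compound 2 to compound 3 (0.36 log units; beyond the scatter) and it lies beyond the scatter, with methoxy in place of hydrogen. Compound 4 gives up that methoxy, so a return towards the values without it is expected. Compound 1 carries the same (4-fluorophenyl)sulfonyl, though it also differs elsewhere, and its 218000 nM supports that expectation. The expected change is an at least 1.8-fold lower number from compound 3 to compound 4 (0.27 log units; that floor lies within the scatter) and points to a lower number. The estimate for compound 4 is 160000 nM within an expected range from 80000 nM to 300000 nM in this assay.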

Compound 4, half-maximal cytotoxic concentration: 157000 nM
Compound 4: middle estimate off by 1.0-fold (0.01 log units), on the high side, and the stated range covers the measured number.
By their numbers in this assay, from the lowest: compounds 2, 4 and 1 (each within the scatter of the next). At a limit, above all of these: compound 3.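

In this assay, for the compounds shown here, fluoro at this position reads like the hydrogen it replaces, with a 1.2-fold higher number from compound 2 to compound 4 (0.09 log units; within the scatter), so methoxy is the only group here whose step from hydrogen, an at least 2.3-fold higher number from compound 2 to compound 3 (0.36 log units; beyond the scatter), lies beyond the scatter; trifluoromethyl in place of fluoro elsewhere on the molecule also makes no clear difference, with a 1.4-fold lower number from compound 1 to compound 4 (0.14 log units; within the scatter). Compound 3 gives > 300000 nM, which is a limit of the assay and not a number. Swapping its methoxy for fluoro gives an at least 1.9-fold lower number from compound 3 to compound 4 (0.28 log units; that floor lies within the scatter), and this figure is only a floor.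

The compounds shown leave open whether other groups at this position, such as a hydroxyl, an ethoxy or a dimethylamino group, read like methoxy or like fluoro. They also leave open whether methoxy gives the same step when fluoro replaces trifluoromethyl elsewhere on the molecule.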